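The compounds below may be only part of what the source reports. "The series", "measured", "known", "first", "only" and "open" are said of these compounds alone.

Compound 1, `Cc1ccc(C(=O)N[C@@H](C(=O)N2CCC(c3ccc(Cl)cc3)CC2)C(C)C)cc1`: 25 nM in an assay on THP-1 cells for displacement of a labelled ligand from C-C chemokine receptor type 1 (Homo sapiens); on this read-out higher numbers stand for weaker inhibition and lower numbers for stronger inhibition
Compound 2, `CC(C)[C@@H](NC(=O)c1cccc(F)c1)C(=O)N1CCC(c2ccc(Cl)cc2)CC1`: 24 nM in this assay
Compound 3, `CC(C)[C@@H](NC(=O)CCCc1ccccc1)C(=O)N1CCC(c2ccc(Cl)cc2)CC1`: 95 nM in this assay

Three compounds share a core and differ only in the group attached to the carbonyl carbon of the amide. Compound 3 gives the highest number of the three in this assay, and its steps to both others lie beyond the scatter: a 3.8-fold higher number from compound 1 to compound 3 (0.58 log units; beyond the scatter) and a 4.0-fold higher number from compound 2 to compound 3 (0.60 log units; beyond the scatter). Compounds 1 and 2 sit together, as a 1.0-fold lower number from compound 1 to compound 2 (0.02 log units; within the scatter) shows.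

Compound 4, `Cc1ccc(CCC(=O)N[C@@H](C(=O)N2CCC(c3ccc(Cl)cc3)CC2)C(C)C)cc1`, is made from compound 3 by the change (4-methylphenyl in place of benzyl on a saturated chain carbon, two bonds along the chain from a carbonyl carbon). Compound 4 keeps an aryl group joined to the carbonyl through a saturated chain rather than directly, so it stays on the side of compound 3 in the pattern set by the two measured steps. For the measured compounds named here, those steps concern the removal of the chain altogether, and no measured step speaks to a shorter chain or to a methyl on the ring. The expectation is therefore a step of modest size at most, with a 1.4-fold lower number from compound 3 to compound 4 (0.13 log units; within the scatter) as the estimate. Compound 4 is expected to give about 70 nM in this assay, within a range of 30 nM to 200 nM.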

Compound 4, half-maximal inhibitory concentration: 105 nM
For compound 4 the middle estimate is 1.5-fold (0.18 log units) below the measured one; the measured number falls inside the stated range.
By their numbers in this assay, from the lowest: compounds 2 and 1 (each within the scatter of the next); then compounds 3 and 4 (each within the scatter of the next).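

In this assay, trading benzyl for 4-methylphenyl on this saturated chain carbon, which turns 3-phenylpropyl into 2-(4-methylphenyl)ethyl, gives a 1.1-fold higher number from compound 3 to compound 4 (0.04 log units; within the scatter), so the two chain groups cannot be told apart here. The new group also stands apart from the aryl groups joined directly to the carbonyl carbon, with a 4.4-fold higher number from compound 2 to compound 4 (0.64 log units; beyond the scatter) and a 4.2-fold higher number from compound 1 to compound 4 (0.62 log units; beyond the scatter), so both compounds with a saturated chain now lie on the same side of that divide. The chain and the methyl vary together in this change, so their separate contributions cannot be read, and no evidence here bears on the result.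

A phenethyl group on the carbonyl carbon would separate the chain from the methyl. On these data alone, a benzyl group there, or a carboxylic acid in place of the methyl, also remains open.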